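Iodo in place of trifluoromethyl on the ortho position

A few compounds are considered here, and "the series" means these few. Any claim that something is new, unique, unknown or untested is made for them only; others in the source may bear on it.

Three compounds share one core and differ only in the group on the aromatic carbon ortho to the large group. Compound 1 `CC1(C)N=C(N)N=C(N)N1c1ccccc1F` carries fluoro there; in an assay for inhibition of Dihydrofolate reductase (Bos taurus), at pH 7.20 (a higher number here means a more potent compound, by a factor of ten per unit of this negative logarithm, a lower number a less potent compound), compound 1 gives 5.41. Compound 2 `CC1(C)N=C(N)N=C(N)N1c1ccccc1O` carries hydroxy and in this assay compound 2 gives 4.18. Compound 3 `CC1(C)N=C(N)N=C(N)N1c1ccccc1C(F)(F)F` carries trifluoromethyl and in this assay compound 3 gives 3.53, the lowest of the three numbers, with compound 2 nearest and compound 1 furthest.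

The next compound, compound 4 `CC1(C)N=C(N)N=C(N)N1c1ccccc1I`, differs from compound 3 as follows: iodo in place of trifluoromethyl on an aromatic carbon. Among the measured compounds shown here, two measured steps bear on this change, both of which end in trifluoromethyl: a number 1.88 log units lower from compound 1 to compound 3 (beyond the scatter) and a number 0.65 log units lower from compound 2 to compound 3 (beyond the scatter). Both run downward, so removing trifluoromethyl is expected to run upward. For the measured compounds named here, no measured step introduces iodo, and the only other single-heavy-atom group in the set, fluoro, stands in compound 1 at 5.41. An upward step beyond the scatter is therefore expected, but smaller than the full return to compound 1. For compound 4 the estimate in this assay is 4.6, with a range from 3.9 to 5.3. This estimate means a step of a number 1.07 log units higher from compound 3 to compound 4 (beyond the scatter).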

Compound 4, logarithm of the reciprocal of the active concentration, log(1/C): 3.75
Beside the measured number, compound 4's estimate is 0.85 log units above it; measured number outside the range, below it.
By their numbers in this assay, from the lowest: compounds 3 and 4 (each within the scatter of the next); then compound 2; then compound 1.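

In this assay, iodo in place of trifluoromethyl on this aromatic carbon recovers essentially nothing: a number 0.22 log units higher from compound 3 to compound 4 (within the scatter), so these two groups cannot be told apart here, although one is a single heavy atom and the other has four. A single heavy atom is therefore no guarantee of a high number at this position, since fluoro and iodo are both single heavy atoms, yet a number 1.66 log units lower from compound 1 to compound 4 (beyond the scatter), and hydroxy also keeps its lead with a number 0.43 log units lower from compound 2 to compound 4 (beyond the scatter). No measurement at hand bears on why iodo and trifluoromethyl read alike while fluoro stands so far from iodo.

The compounds shown leave open where chloro, bromo and methyl would fall on this position, and so whether the drop from fluoro to the level shared by iodo and trifluoromethyl is gradual or abrupt. They also leave open whether an amine or a methoxy group would match hydroxy, which sits apart from both fluoro and iodo.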